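The source may report more compounds than this note shows. Statements on the series, on what has been measured and on what is new or still open speak of the compounds shown alone.

Working notes on the series. Compound 3 `CCCCc1ccc(CN(Cc2ccccc2)C(C)=O)c(=O)n1Cc1ccc(-c2ccccc2-c2nn[nH]n2)cc1` holds the lowest of the three numbers in a functional assay (aorta) for antagonist activity, with Oryctolagus cuniculus as the target; a lower number here means a stronger inhibitor, a higher number a weaker inhibitor: compound 3 gives 1 nM. Compound 1 `CCCCc1ccc(CNC(=O)OC(C)(C)C)c(=O)n1Cc1ccc(-c2ccccc2-c2nn[nH]n2)cc1` gives 10 nM and compound 2 `CCCCNC(=O)NCc1ccc(CCCC)n(Cc2ccc(-c3ccccc3-c3nn[nH]n3)cc2)c1=O` gives 10 nM; the step of no change at the digits printed from compound 1 to compound 2 (within the scatter) lies within the scatter, whereas a 10-fold lower number from compound 1 to compound 3 (1.00 log units; beyond the scatter) and a 10-fold lower number from compound 2 to compound 3 (1.00 log units; beyond the scatter) both lie beyond it. Compound 4 `CCCCc1ccc(CN(C)S(=O)(=O)c2ccccc2)c(=O)n1Cc1ccc(-c2ccccc2-c2nn[nH]n2)cc1` differs from compound 3 by methyl(phenylsulfonyl)amino in place of acetyl(benzyl)amino on a saturated chain carbon bound to an aromatic carbon. For the measured compounds named here, no measured step replaces the acetyl(benzyl)amino group itself; the two steps that reached it each lowered the number, so moving away from it is expected to raise the number modestly, by a 3.0-fold higher number from compound 3 to compound 4 (0.48 log units; beyond the scatter). Compound 4 is therefore expected to give 3 nM in this assay, with a range of 1 nM to 20 nM.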

Compound 4, half-maximal inhibitory concentration: 2 nM
For compound 4 the middle estimate is 1.5-fold (0.18 log units) above the measured one; measured number inside the range.
By their numbers in this assay, from the lowest: compounds 3 and 4 (each within the scatter of the next); then compounds 1 and 2 (each within the scatter of the next).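

In this assay, methyl(phenylsulfonyl)amino takes the place of acetyl(benzyl)amino with no change beyond the scatter (a 2.0-fold higher number from compound 3 to compound 4 (0.30 log units; within the scatter)), so at this saturated chain carbon the low number does not depend on the acetyl(benzyl)amino group. The new group also separates from the two earlier groups (a 5.0-fold lower number from compound 1 to compound 4 (0.70 log units; beyond the scatter); a 5.0-fold lower number from compound 2 to compound 4 (0.70 log units; beyond the scatter)), so the gain seen with compound 3 recurs with a sulfonyl group. No evidence bearing on this result is available. Open still is whether a free amine or a carboxylic acid at this carbon keeps the number low, and whether the methyl or the phenylsulfonyl part of the new group matters.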